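A few compounds are considered here, and "the series" means these few. Any claim that something is new, unique, unknown or untested is made for them only; others in the source may bear on it.

Series notes, pharmacokinetics. Three compounds on the shared core carry a number in an ADME assay on the whole organism (plasma, strain Sprague-Dawley) for pharmacokinetics, with Rattus norvegicus as the target, at a dose of 2 mg/kg by the oral route; a lower number here means less compound in the circulation, a higher number more compound in the circulation at the dose given. Compound 1 `Cc1ccc(C(=O)NC2CC2)cc1-c1cc2cnnc(-c3ccc(F)cc3F)c2n(C)c1=O` gives 7630 ng.h/mL. For the measured compounds named here, compound 2 `Cc1c(F)cc(C(=O)NC2CC2)cc1-c1cc2cnnc(-c3ccc(F)cc3F)c2n(C)c1=O` gives 6740 ng.h/mL; the only measured single-point step, a 1.1-fold lower number from compound 1 to compound 2 (0.05 log units; within the scatter), is a fluoro for hydrogen on an aromatic carbon and leaves the number where it was. Going by the values given here, compound 3 `Cc1cnc(C(=O)NC2CC2)cc1-c1cc2cnnc(-c3ccccc3C)c2n(C)c1=O` gives 543 ng.h/mL, the lowest of the three numbers, well apart from compound 2 and from compound 1, a gap beyond the scatter in both cases; no single-point step connects compound 3 to either.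

Compound 4 `Cc1cnc(C(=O)NC2CC2)cc1-c1cc2cnnc(-c3ccc(F)cc3C)c2n(C)c1=O` differs from compound 3 by fluoro in place of hydrogen on an aromatic carbon. Among the compounds with values here, the one step that bears on it is the fluoro-for-hydrogen change from compound 1 to compound 2, which came out within the scatter, so nothing beyond the scatter is expected here either, in either direction. For compound 4 the expected step from compound 3 is a 1.1-fold higher number from compound 3 to compound 4 (0.04 log units; within the scatter). Compound 4 is therefore estimated at 600 ng.h/mL, with a range from 250 ng.h/mL to 1500 ng.h/mL, to be set against the measured number.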

Compound 4, area under the concentration-time curve: 2410 ng.h/mL
Compound 4: the middle estimate sits 4.0-fold (0.60 log units) below what was measured; measured number above the stated range.
By their numbers in this assay, from the lowest: compound 3; then compound 4; then compounds 2 and 1 (each within the scatter of the next).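

Fluoro in place of hydrogen on this aromatic carbon, para to a large group and meta to a methyl group, is not a neutral change in this assay: the step is a 4.4-fold higher number from compound 3 to compound 4 (0.65 log units; beyond the scatter). For the compounds shown here, the 2-methylphenyl to 4-fluoro-2-methylphenyl change is the only fluoro-for-hydrogen step here that moves the number beyond the scatter. A within-scatter reading on one core therefore does not carry over to the other, and the two readings stand clearly apart: the same change on two cores in this assay, a 1.1-fold lower number (0.05 log units; within the scatter) from compound 1 to compound 2 and a 4.4-fold higher number (0.65 log units; beyond the scatter) from compound 3 to compound 4, 5.0-fold (0.70 log units) apart, beyond the scatter of two such steps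

The compounds shown do not separate the contribution of the core from that of the place of the fluoro. As far as these compounds go, it also remains open whether a chloro, a methoxy or a nitrile at this position would shift the number as the fluoro does.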